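Aminothiophene piperazines: swapping pyridin-4-yl for 2,4-difluorophenyl

The source may hold more compounds than are shown below. What is called first, only, known or untested is meant among the compounds shown, and "the series" means these compounds.

Measured compounds and their values:
- compound 1, `Nc1scc(CN2CCN(c3cc(Cl)cc(Cl)c3)CC2)c1C(=O)c1ccc(Cl)cc1`, gives -22% in a functional assay on CHO cells with adenosine receptor A1 (Homo sapiens) as the target, read by cAMP accumulation and immunoassay, with a stated time of 6 min, tested at 0.1 uM; on this read-out higher numbers stand for a weaker effect at the one concentration tested and lower numbers for a stronger effect
- compound 2, `COc1ccc(N2CCN(Cc3csc(N)c3C(=O)c3ccc(Cl)cc3)CC2)cc1`, gives 0%
- compound 3, `Nc1scc(CN2CCN(c3ccncc3)CC2)c1C(=O)c1ccc(Cl)cc1`, gives 1.4%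

Compound 3 holds the highest of the three numbers. Its nearest neighbour is compound 2, whose number lies lower only by a number 1.4 percentage points higher from compound 2 to compound 3 (within the scatter), which is within the scatter. Compound 1 is the furthest away: the step of a number 23.4 percentage points higher from compound 1 to compound 3 (beyond the scatter) is beyond the scatter, as is the related step of a number 22 percentage points higher from compound 1 to compound 2 (beyond the scatter).

Compound 4, `Nc1scc(CN2CCN(c3ccc(F)cc3F)CC2)c1C(=O)c1ccc(Cl)cc1`, is the next compound to be measured. It differs from compound 3 in one place: 2,4-difluorophenyl in place of pyridin-4-yl on an amine nitrogen in a ring. The measured steps that bear on this change are those leading away from compound 1, whose 3,5-dichlorophenyl on the amine nitrogen in the ring gave the lowest number of the set. Compound 4 returns to a halogen-bearing phenyl on that nitrogen, though with two fluorines rather than two chlorines, so the step of a number 23.4 percentage points higher from compound 1 to compound 3 (beyond the scatter) is expected to be partly reversed, while the unchanged reading between compound 2 and compound 3 offers no further guidance. A modest downward step is therefore expected, a number 11.4 percentage points lower from compound 3 to compound 4 (beyond the scatter), and compound 4 is estimated at -10%, within a range from -30% to 10%.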

Compound 4, a percentage reported as activity, at one concentration (the size of the read-out at that concentration, not a potency): -17%
Compound 4: the middle estimate sits 7 percentage points above what was measured; measured number inside the range.
By their numbers in this assay, from the lowest: compounds 1 and 4 (each within the scatter of the next); then compounds 2 and 3 (each within the scatter of the next).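

In this assay, the 2,4-difluorophenyl on the amine nitrogen in the ring gives a number 18.4 percentage points lower from compound 3 to compound 4 (beyond the scatter) and, against the 4-methoxyphenyl, a number 17 percentage points lower from compound 2 to compound 4 (beyond the scatter) as well, so the low reading of compound 1 is no longer the result of a single substituted phenyl. Set against the 3,5-dichlorophenyl, the same group gives a number 5 percentage points higher from compound 1 to compound 4 (within the scatter) and the two cannot be told apart here despite their different halogens, so the four compounds fall into two groups, with the halogen-bearing phenyls in one and the 4-methoxyphenyl and pyridin-4-yl in the other, and none of the four goes against this split. Nothing on hand accounts for this split between the groups at this position.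

The compounds shown leave open whether a halogen is needed at all, since a plain phenyl, a 4-chlorophenyl or a 2-fluorophenyl on that nitrogen would each test a different part of the split. They also leave open how far these readings at one concentration reflect potency, as each number is the size of the effect at that concentration alone.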